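The source may report more compounds than this note shows. Statements on the series, on what has been measured and on what is new or still open speak of the compounds shown alone.

Values in a functional assay on MCF7 cells (Homo sapiens) for inhibition, read by MTT assay; on this read-out higher numbers stand for weaker inhibition of growth and lower numbers for stronger inhibition of growth:
- Compound 1 `COc1cc2oc(-c3cccc(NC(=O)c4cccc(Br)c4)c3)cc(=O)c2c(O)c1OC`: 6940 nM
- Compound 2 `COc1ccc(C(=O)Nc2cccc(-c3cc(=O)c4c(O)c(OC)c(OC)cc4o3)c2)cc1`: 2050 nM
- Compound 3 `COc1cccc(C(=O)Nc2cccc(-c3cc(=O)c4c(O)c(OC)c(OC)cc4o3)c2)c1`: not yet measured

Of the two measured compounds, compound 2 has the lower number, at 2050 nM, so it is the stronger growth inhibitor of the pair. Compound 3 contains the same atoms as compound 2, joined differently: 3-methoxyphenyl in place of 4-methoxyphenyl on a carbonyl carbon.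

Going by the values given here, only one measured step bears on this change: a 3.4-fold lower number from compound 1 to compound 2 (0.53 log units; beyond the scatter). That modest step replaced 3-bromophenyl with 4-methoxyphenyl, so it changed the group itself and offers only indirect guidance. Among the compounds with values here, no measured pair compares 3-methoxyphenyl directly with 4-methoxyphenyl. The slight lean towards a higher number in this assay rests on compound 1 at 6940 nM, which carries 3-bromophenyl, and a single compound is thin support. The expected change is smaller than the measured one, and the estimate is a 1.7-fold higher number from compound 2 to compound 3 (0.22 log units; within the scatter). For compound 3 the estimated value is 3400 nM, with an expected range of 1300 nM to 9000 nM.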

Compound 3, concentration for 50% growth inhibition: 35600 nM
Beside the measured number, compound 3's estimate is 10-fold (1.02 log units) below it, outside the stated range (above it).
By their numbers in this assay, from the lowest: compound 2; then compound 1; then compound 3.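

In this assay, shifting the methoxy group from 4-methoxyphenyl to 3-methoxyphenyl on the amide carbonyl, with no atom gained or lost, gives a 17-fold higher number from compound 2 to compound 3 (1.24 log units; beyond the scatter), so where the methoxy sits on this ring matters a great deal. The comparison of 3-methoxyphenyl with 3-bromophenyl gives a 5.1-fold higher number from compound 1 to compound 3 (0.71 log units; beyond the scatter), which shows that methoxy is not favourable in itself: among these three compounds, it gives the lowest number as 4-methoxyphenyl and the highest as 3-methoxyphenyl, with 3-bromophenyl falling in the middle. No measurement here accounts for the size of the effect of this shift.

The compounds shown leave open whether 4-bromophenyl would also give a lower number than 3-bromophenyl, which would indicate whether the preference belongs to the place on the ring generally or to methoxy alone. They also leave open how an unsubstituted phenyl ring, or a ring carrying a hydroxy group or an amine, would compare on the same carbonyl.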